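Cytotoxicity on THP-1 Cells Across Three Amide Variations

The compounds below may be only part of what the source reports. "The series", "measured", "known", "first", "only" and "open" are said of these compounds alone.

Measured compounds:
compound 1 `Cc1ccccc1-c1cnc(NC(=O)c2ccc(F)cc2)n1C`: > 50000 nM
compound 2 `Cn1c(-c2ccccc2)cnc1NC(=O)c1ncc[nH]1`: > 100000 nM
compound 3 `Cn1c(-c2ccccc2Cl)cnc1NC(=O)c1ccc(F)cc1`: > 50000 nM

The read-out is a toxicity assay on THP-1 cells (Homo sapiens) for inhibition; a higher number here means that more compound is tolerated, a lower number that less compound is tolerated. In it compound 1 gives > 50000 nM, which is a limit of the assay. Compound 2 gives > 100000 nM, also a limit. Compound 3 gives > 50000 nM, again a limit, so it stands at the limit of > 50000 nM in this assay, at which 2 of the 3 values shown sit, and nothing finer is known of it. Within the data shown here, the only measured step, a step that the two limits leave unreadable from compound 1 to compound 3, is unreadable. Compound 4 `Cn1c(-c2ccccc2Cl)cnc1NC(=O)c1ncc[nH]1` differs from compound 3 by 1H-imidazol-2-yl in place of 4-fluorophenyl on a carbonyl carbon. Compound 2, which carries the same 1H-imidazol-2-yl on its carbonyl carbon, sits at the limit of > 100000 nM in this assay, at which 1 of the 3 values shown sits. No readable step bears on this change, so the expected step that the limit leaves unreadable from compound 3 to compound 4 is none beyond the scatter. Compound 4 is expected at 100000 nM, between 50000 nM and 300000 nM, most likely reported only as a limit.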

Compound 4, half-maximal cytotoxic concentration: > 50000 nM
Compound 4 ended at the assay's limit; the forecaster's own chance of this, stated with the estimate: 85%; the middle value lies beyond the limit too.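

No new step can be read, since compound 2, compound 3 and compound 4 all stand only at limits in this assay. The compounds shown leave open what concentration actually harms these cells, and whether any of these changes shifts it.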